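The source may hold more compounds than are shown below. What is called first, only, known or untested is meant among the compounds shown, and "the series" means these compounds.

Measured in an assay for inhibition of Amine oxidase [flavin-containing] B (Rattus norvegicus); on this read-out higher numbers stand for weaker inhibition and lower numbers for stronger inhibition:

- compound 1, `C[C@H](Nc1cc(=O)oc2cc(OCc3ccccc3)ccc12)C(N)=O`, gives 680 nM
- compound 2, `NC(=O)Cc1cc(=O)oc2cc(OCc3ccccc3)ccc12`, gives 200 nM
- compound 3, `CC(C(N)=O)c1cc(=O)oc2cc(OCc3ccccc3)ccc12`, gives 100 nM

Among these three, compound 3 stands at the lowest number. Its nearest neighbour is compound 2, and the step of a 2.0-fold lower number from compound 2 to compound 3 (0.30 log units; within the scatter) lies within the scatter, so the two cannot be told apart. The step of a 6.8-fold lower number from compound 1 to compound 3 (0.83 log units; beyond the scatter) is beyond the scatter, as is a 3.4-fold lower number from compound 1 to compound 2 (0.53 log units; beyond the scatter).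

Compound 4, `CNCc1cc(=O)oc2cc(OCc3ccccc3)ccc12`, is not yet measured. Its change from compound 3 is (methylamino)methyl in place of 1-carbamoylethyl on an aromatic carbon. Going by the values given here, no measured step tests this exact change: the step from compound 2 to compound 3 only added the methyl on the chain carbon, and the two steps from compound 1 altered the link to the ring while keeping the amide. All three measured compounds carry the amide, which compound 4 lacks, so the expectation rests on little. A modest rise in the number, that is somewhat weaker inhibition, is expected for compound 4, with wide uncertainty: the expected step is a 4.0-fold higher number from compound 3 to compound 4 (0.60 log units; beyond the scatter). The estimate for compound 4 in this assay is 400 nM, within a range from 80 nM to 2500 nM.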

Compound 4, half-maximal inhibitory concentration: 28 nM
Beside the measured number, compound 4's estimate is 14-fold (1.15 log units) above it; the whole stated range lies above it.
By their numbers in this assay, from the lowest: compound 4; then compounds 3 and 2 (each within the scatter of the next); then compound 1.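

Measured by this assay, the amide is not needed at this place opposite the ring oxygen: putting (methylamino)methyl in place of 1-carbamoylethyl gives a 3.6-fold lower number from compound 3 to compound 4 (0.55 log units; beyond the scatter) and leaves a group with fewer heavy atoms and no carbonyl. The simpler amide side chain behaves the same way, with methylamino in place of carbamoyl giving a 7.1-fold lower number from compound 2 to compound 4 (0.85 log units; beyond the scatter) on the same chain carbon, which makes compound 4 the strongest inhibitor of the four. A nitrogen in the group is not enough on its own: compound 1 also has one, in its (1-carbamoylethyl)amino group, and the step is a 24-fold lower number from compound 1 to compound 4 (1.39 log units; beyond the scatter) in size.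

Nothing shown explains why the (methylamino)methyl group gives the lowest number. Open, going by these compounds, is how an aminomethyl group, a (dimethylamino)methyl group, a longer chain ending in an amine, or a carboxylic acid would fare at this place.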